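A Ring Amine Substituent Swap and Its Expected Outcome

This account rests on a few compounds, and the source may have more. Where it says the series, first, only, none or still open, it means among the compounds named here.

Compound 1, `Nc1scc(CN2CCN(c3cccc(Cl)c3Cl)CC2)c1C(=O)c1ccc(Cl)cc1`: 1%
Compound 2, `Nc1scc(CN2CCN(c3ccc(OC(F)(F)F)cc3)CC2)c1C(=O)c1ccc(Cl)cc1`: 0%

Two compounds share one core and differ only in the group on an amine nitrogen in a ring. In a functional assay on CHO cells with adenosine receptor A1 (Homo sapiens) as the target, read by cAMP accumulation and immunoassay, with a stated time of 6 min, tested at 0.01 uM (a higher number here means a weaker effect of the compound at the concentration tested, a lower number a stronger effect), compound 1 gives 1%, and in the same assay compound 2 gives 0%. The step between them is a number 1 percentage points lower from compound 1 to compound 2 (within the scatter). Of the two numbers shown, the one for compound 2 is the smaller, yet the gap to compound 1 is within the scatter, so the two cannot be told apart.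

Compound 3, `Nc1scc(CN2CCN(C3CCCCCC3)CC2)c1C(=O)c1ccc(Cl)cc1`, has not yet been measured in this assay. It differs from compound 2 as follows: cycloheptyl in place of 4-(trifluoromethoxy)phenyl on an amine nitrogen in a ring. Within the data shown here, only one measured step bears on this change, a number 1 percentage points lower from compound 1 to compound 2 (within the scatter), and that step is within the scatter. Both measured compounds give read-outs close to zero, and nothing in the numbers shown points to a step beyond the scatter. The expected change is therefore a number 2 percentage points higher from compound 2 to compound 3 (within the scatter). Compound 3 is estimated at 2%, with a range from -8% to 14%.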

Compound 3, a percentage reported as activity, at one concentration (the size of the read-out at that concentration, not a potency): 2.9%
Estimate against measurement, compound 3: 0.9 percentage points below; low and high end bracket the measured number.
By their numbers in this assay, from the lowest: compounds 2, 1 and 3 (each within the scatter of the next).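

Compound 3 carries cycloheptyl, a seven-membered non-aromatic ring of carbon only, on the amine nitrogen in a ring, where compound 1 and compound 2 carry a six-membered aromatic ring, and in this assay the steps are a number 2.9 percentage points higher from compound 2 to compound 3 (within the scatter) and a number 1.9 percentage points higher from compound 1 to compound 3 (within the scatter). An aromatic ring at this place is therefore not needed for a read-out that cannot be told apart from those of compound 1 and compound 2 at the single concentration tested, and the loss of the oxygen and the fluorines of 4-(trifluoromethoxy)phenyl leaves compound 3 equally indistinguishable from compound 2. No information is available on why these three groups give such similar read-outs.

The compounds shown leave open what a much smaller group on this nitrogen, such as methyl, or a chain ending in a carboxylic acid or an amine, would give. Since all three read-outs come from one concentration, they also leave open whether compound 1, compound 2 and compound 3 would give a stronger or weaker effect than one another at other concentrations.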